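A few compounds are considered here, and "the series" means these few. Any claim that something is new, unique, unknown or untested is made for them only; others in the source may bear on it.

Values measured so far in a functional assay on KB 3-1 cells (Homo sapiens) for antiproliferative activity, read by MTT assay (a higher number here means a weaker inhibitor, a lower number a stronger inhibitor), for the series:

- compound 1 `C[C@@H]1[C@@H]2[C@@H](CC(=O)[C@H]2C)C[C@H]1O[Si](c1ccccc1)(c1ccccc1)C(C)(C)C` – 7400 nM
- compound 2 `C=CC[C@@H]1C(=O)C[C@H]2C[C@@H](O[Si](c3ccccc3)(c3ccccc3)C(C)(C)C)[C@H](C)[C@H]21` – 16200 nM
- compound 3 `CC(C)=CC[C@@H]1C(=O)C[C@H]2C[C@@H](O[Si](c3ccccc3)(c3ccccc3)C(C)(C)C)[C@H](C)[C@H]21` – 21700 nM

Compound 1 holds the lowest number of the three, and its steps to both other compounds lie beyond the scatter. The next structure is compound 4 `C=CC[C@@H]1[C@@H]2[C@@H](CC(=O)[C@H]2C)C[C@H]1O[Si](c1ccccc1)(c1ccccc1)C(C)(C)C` and the change to it is vinyl in place of hydrogen on a saturated chain carbon bound to a saturated ring carbon on the core of compound 1. The same difference can be read as methyl to allyl.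

The closest evidence is the same kind of exchange, a 2.2-fold higher number from compound 1 to compound 2 (0.34 log units; beyond the scatter), although compound 2 and compound 4 are different structures. The larger 2-methylprop-1-en-1-yl gives a 2.9-fold higher number from compound 1 to compound 3 (0.47 log units; beyond the scatter) in the same direction. The two groups barely separate, with a 1.3-fold higher number from compound 2 to compound 3 (0.13 log units; within the scatter) between them. Among the compounds with values here, both measured exchanges raised the number, and no measured compound goes against this, but there are only two such exchanges and neither gives compound 4 itself.

A modest move toward a higher number in this assay is therefore expected, and the expected size is a 1.9-fold higher number from compound 1 to compound 4 (0.28 log units; within the scatter) in this assay. Compound 4 is estimated at 14000 nM with an expected range from 6000 nM to 30000 nM in this assay.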

Compound 4, half-maximal inhibitory concentration: 20300 nM
Compound 4: the middle estimate sits 1.5-fold (0.16 log units) below what was measured, within the range that was stated.
By their numbers in this assay, from the lowest: compound 1; then compounds 2, 4 and 3 (each within the scatter of the next).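

In this assay, the rise on going to compound 4 (a 2.7-fold higher number from compound 1 to compound 4 (0.44 log units; beyond the scatter)) shows that the methyl to allyl change raises the number at this position too, so the effect seen with compound 2 is not confined to one place on the core of compound 1. Compound 2 (16200 nM) and compound 4 (20300 nM) lie within the scatter of each other, so the shown values do not separate these two placements of the same group, and all three compounds carrying a longer unsaturated group stand beyond the scatter from compound 1. No measurement in hand accounts for the rise in the number at this position.

Open, going by these compounds, is whether the double bond of the added group matters at all, which a saturated propyl chain on this saturated chain carbon would test against the vinyl exchange. Also open is how this position responds to a group of a different kind, such as an amine or a carboxylic acid at the end of the chain, since every added group shown here is a plain hydrocarbon.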